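From pyrrolidin-3-yl to 4-(trifluoromethyl)phenyl on the carbonyl carbon

The source may report more compounds than this note shows. Statements on the series, on what has been measured and on what is new or still open speak of the compounds shown alone.

In a functional assay on DU-145 cells (Homo sapiens) for inhibition, read by trypan blue exclusion, with a stated time of 96 h (on this read-out lower numbers stand for stronger inhibition of growth and higher numbers for weaker inhibition of growth), compound 3 (`O=C(/C(=C\c1ccc(O)c([N+](=O)[O-])c1)SCc1ccc(Br)cc1)C1CCNC1`) gives > 100000 nM and that figure is a limit of the assay, not a number.

In this assay compound 1 (`O=C(/C(=C\c1ccc(O)c([N+](=O)[O-])c1)SCc1ccc(Br)cc1)c1c(F)c(F)c(F)c(F)c1F`) gives 10000 nM and compound 2 (`N#Cc1ccc(C(=O)/C(=C\c2ccc(O)c([N+](=O)[O-])c2)SCc2ccc(Br)cc2)cc1`) gives 10000 nM on the same scale. Compound 4 (`O=C(/C(=C\c1ccc(O)c([N+](=O)[O-])c1)SCc1ccc(Br)cc1)c1ccc(C(F)(F)F)cc1`) has not yet been measured. It carries 4-(trifluoromethyl)phenyl in place of pyrrolidin-3-yl on a carbonyl carbon.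

Three measured steps at this carbon bear on the change. Between the two aromatic groups, the data show no change at the digits printed from compound 1 to compound 2 (within the scatter) on this carbonyl carbon. With pyrrolidin-3-yl in place of either aromatic group, they show an at least 10-fold higher number from compound 1 to compound 3 (1.00 log units; beyond the scatter) and an at least 10-fold higher number from compound 2 to compound 3 (1.00 log units; beyond the scatter) at the same carbon. Compound 4 again has an aromatic ring there, so it is expected to fall with compound 1 at 10000 nM and compound 2 at 10000 nM in this assay rather than with compound 3. The estimated outcome is an at least 10-fold lower number from compound 3 to compound 4 (1.00 log units; beyond the scatter) toward stronger inhibition of growth. For compound 4 the estimate in this assay is 10000 nM with an expected range of 3000 nM to 30000 nM around it.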

Compound 4, concentration for 50% growth inhibition: 10000 nM
Beside the measured number, compound 4's estimate shows no gap at the digits printed, within the range that was stated.
By their numbers in this assay, from the lowest: compounds 1, 2 and 4 (each within the scatter of the next). At a limit, above all of these: compound 3.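

In this assay, trifluoromethyl in place of cyano on an aromatic carbon gives no change at the digits printed from compound 2 to compound 4 (within the scatter), and 4-(trifluoromethyl)phenyl in place of 2,3,4,5,6-pentafluorophenyl gives no change at the digits printed from compound 1 to compound 4 (within the scatter), so three different aromatic groups on this carbonyl carbon now read alike. Going from pyrrolidin-3-yl to 4-(trifluoromethyl)phenyl gives an at least 10-fold lower number from compound 3 to compound 4 (1.00 log units; beyond the scatter), which repeats with a third aromatic group the gap already seen with the two earlier ones and ties that gap to the exchange of the non-aromatic ring for an aromatic ring rather than to any one substituent on the ring. Compound 3 holds a limit of the assay and not a number, so the full size of this step stays unknown: the limit of > 100000 nM in this assay, at which 1 of the 4 values shown sits.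

Still open, from the compounds shown here alone, is whether the loss of aromatic character or the ring nitrogen of pyrrolidin-3-yl sets compound 3 apart from the others, and a cyclohexyl group on the carbonyl carbon would separate the two. An unsubstituted phenyl ring, or a phenyl ring carrying an amine or a carboxylic acid, would show how far the shared reading of the aromatic groups extends beyond fluorine-bearing and nitrile-bearing rings.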